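Swapping a Phenyl for an Isopentyl Tail

The compounds below may be only part of what the source reports. "The series", "measured", "known", "first", "only" and "open" are said of these compounds alone.

Of the compounds shown here, three of a shared core have been measured in an ADME assay on HepG2 cells (Homo sapiens) for cytotoxicity, read by luminescence, CellTiter-Glo and ATP content, with a stated time of 72 h; a higher number here means that more compound is needed for the effect, a lower number that less compound is needed. Compound 1 `COc1ccc(Oc2ccc3c(NCCCNCc4cc(F)ccc4OC)ccnc3c2)cc1` gives 7000 nM. Compound 2 `CC(C)Cc1ccc2c(NCCCNCc3ccco3)ccnc2c1` gives 16000 nM. Among the compounds with values here, compound 3 `c1ccc(-c2ccc3c(NCCCNCc4ccco4)ccnc3c2)cc1` gives 5920 nM, the lowest of the three numbers; against compound 1 the gap is within the scatter, while the step of a 2.7-fold lower number from compound 2 to compound 3 (0.43 log units; beyond the scatter) is beyond it and is the only single-point change among the measured compounds.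

Compound 4 `CC(C)CCc1ccc2c(NCCCNCc3ccco3)ccnc2c1` has not yet been measured. It differs from compound 3 in one place: isopentyl in place of phenyl on an aromatic carbon. Within the data shown here, the measured step that bears on this is the one from compound 2 to compound 3, where phenyl in place of isobutyl on an aromatic carbon lowered the number modestly. Compound 4 carries an isopentyl, a chain like the isobutyl of compound 2 rather than the ring of compound 3, so the change should run the other way. A modest rise in this assay is therefore expected, the estimated step being a 2.0-fold higher number from compound 3 to compound 4 (0.31 log units; beyond the scatter), landing between compound 3 and compound 2 because of 16000 nM for compound 2. Compound 4 is expected to give about 12000 nM, with a range from 6000 nM to 24000 nM.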

Compound 4, half-maximal effective concentration: 11200 nM
For compound 4 the middle estimate is 1.1-fold (0.03 log units) above the measured one, within the range that was stated.
By their numbers in this assay, from the lowest: compounds 3, 1, 4 and 2 (each within the scatter of the next, the first and the last beyond it).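

In this assay the swap of the phenyl ring for the isopentyl chain on this aromatic carbon gives a 1.9-fold higher number from compound 3 to compound 4 (0.28 log units; within the scatter) and so cannot be told from the usual scatter of repeated measurements, whereas a 2.7-fold lower number from compound 2 to compound 3 (0.43 log units; beyond the scatter) stands clear of it. The two chains also sit close together, since the change from the isobutyl of compound 2 to the isopentyl of compound 4 gives a 1.4-fold lower number from compound 2 to compound 4 (0.15 log units; within the scatter) and also stays within the scatter, so extending the chain in this way shows no readable effect in these compounds. Only the isobutyl and phenyl pair is therefore clearly separated at this position, and nothing available here accounts for that difference.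

On these data alone, whether a different kind of group on the same aromatic carbon, such as an amine or a carboxylic acid, would shift the number beyond the scatter remains open. So does the question of whether a longer chain than isopentyl, or a phenyl ring carrying a methoxy group, would separate more clearly from the compounds shown.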